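Aryl amide in place of a fluoropiperidine urea

The compounds below may be only part of what the source reports. "The series", "measured", "known", "first", "only" and "open" are said of these compounds alone.

Compound 1 `O=C([C@H]1CC2CCC1C2)N1CC(c2nc(-c3ccccc3)no2)C1`: 120 nM
Compound 2 `O=C(N1CCC(F)CC1)N1CC(c2nc(-c3cccc(Cl)c3)no2)C1`: 990 nM
Compound 3 `O=C([C@H]1CC2CCC1C2)N1CC(c2nc(-c3cccc(F)c3)no2)C1`: 72 nM

Compound 2 gives the highest number of the three in an assay on HEK293 cells for positive allosteric modulation of metabotropic glutamate receptor 5 (Homo sapiens), read by FLIPR; a lower number here means that less compound is needed, a higher number that more compound is needed for the effect; the step of a 1.7-fold lower number from compound 1 to compound 3 (0.22 log units; within the scatter) stays within the scatter, while compound 2 lies well beyond the scatter from both. Compound 4 `O=C(c1ccccc1F)N1CC(c2nc(-c3cccc(Cl)c3)no2)C1` differs from compound 2 in one place: 2-fluorophenyl in place of 4-fluoropiperidin-1-yl on a carbonyl carbon. Among the compounds with values here, no measured step touches this change, since compounds 1 and 3 differ from compound 2 in two places at once, and the only measured step concerns a fluoro on an aromatic carbon. The expectation therefore rests on the gap between compound 2 and the two bicyclic amides; the estimated step is a 3.3-fold lower number from compound 2 to compound 4 (0.52 log units; beyond the scatter), with wide uncertainty. Compound 4 is thus expected at 300 nM, between 80 nM and 1200 nM.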

Compound 4, half-maximal effective concentration: > 10000 nM
Compound 4: only a limit was reported; the forecaster's own chance of this, stated with the estimate: 5%; middle value at least 33-fold (1.52 log units) from the limit.
By their numbers in this assay, from the lowest: compounds 3 and 1 (each within the scatter of the next); then compound 2. At a limit, above all of these: compound 4.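

With the rest of the molecule held constant, 2-fluorophenyl in place of 4-fluoropiperidin-1-yl on the carbonyl carbon gives an at least 10-fold higher number from compound 2 to compound 4 (1.00 log units; beyond the scatter) in this assay. This is the first change shown at this position, and it shows that a six-membered ring of the same heavy-atom count is not enough to keep the effect. Compound 4 gives only a limit, so the full size of this step stays unknown: the limit of > 10000 nM in this assay, at which 1 of the 4 values shown sits.

The compounds shown leave open whether the aromatic ring or its fluoro accounts for this step. A plain phenyl or a pyridyl group on this carbonyl carbon would separate the two.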